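A few compounds are considered here, and "the series" means these few. Any claim that something is new, unique, unknown or untested is made for them only; others in the source may bear on it.

In an ADME assay on MRC5 cells (Homo sapiens) for cytotoxicity, read by MTT assay, with a stated time of 72 h (on this read-out lower numbers stand for higher toxicity in this test and higher numbers for lower toxicity in this test), the two measured compounds offer little to go on. Compound 1 (`OC[C@H]1O[C@@H](n2cc(F)c3c(-c4ccccc4)ncnc32)[C@H](O)[C@@H]1O`) gives > 50000 nM, which is a limit of the assay and not a number. Compound 2 (`OC[C@H]1O[C@@H](n2cc(Cl)c3c(-c4ccccc4)ncnc32)[C@H](O)[C@@H]1O`) gives > 50000 nM, which is also a limit. Compound 2 therefore has no exact value, and the whole picture is the limit of > 50000 nM in this assay, at which 2 of the 2 values shown sit.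

The next compound, compound 3 (`OC[C@H]1O[C@@H](n2cc(Cl)c3c(-c4ccco4)ncnc32)[C@H](O)[C@@H]1O`), keeps the chloro and carries furan-2-yl in place of phenyl on an aromatic carbon. Among the compounds with values here, the only measured step is a step that the two limits leave unreadable from compound 1 to compound 2, with chloro in place of fluoro on an aromatic carbon. That step involves a different change and has no readable size, so it gives no measure for this one. Neither measured compound carries furan-2-yl.

With compound 2 at the limit of > 50000 nM, the only readable direction in this assay is towards lower numbers. The expected step is an at least 5.0-fold lower number from compound 2 to compound 3 (0.69 log units; beyond the scatter), a loose estimate, and another limit remains possible. The estimate for compound 3 is 10000 nM, with an expected range from 500 nM to 50000 nM.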

Compound 3, half-maximal cytotoxic concentration: > 50000 nM
Compound 3 was reported as a limit; the forecaster's own chance of this, stated with the estimate: 40%; at least 5.0-fold (0.69 log units) between middle value and limit.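

No step can be read from compound 2 to compound 3, because both are reported only as a limit and not as a number: the limit of > 50000 nM in this assay, at which 3 of the 3 values shown sit. The compounds shown leave open whether swapping fluoro, chloro, phenyl or furan-2-yl changes the read-out in this assay at all, and by how much.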